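The compounds below may be only part of what the source reports. "The series", "measured", "known", "first", "only" and "open" are said of these compounds alone.

Measured compounds in an assay on microsomes from liver for inhibition of 3-hydroxy-3-methylglutaryl-coenzyme A reductase (Rattus norvegicus); a lower number here means a stronger inhibitor, a higher number a weaker inhibitor:
Compound 1, `CCN(Cc1ccccc1)C(=O)c1nn(-c2ccc(F)cc2)c(OC[C@@H](O)C[C@@H](O)CC(=O)O)c1C(C)C`, gives 14 nM.
Compound 2, `Cc1ccc(CN(C)C(=O)c2nn(-c3ccc(F)cc3)c(OC[C@@H](O)C[C@@H](O)CC(=O)O)c2C(C)C)cc1`, gives 37 nM.
Compound 3, `Cc1cccc(CNC(=O)c2nn(-c3ccc(F)cc3)c(OC[C@@H](O)C[C@@H](O)CC(=O)O)c2C(C)C)c1`, gives 4.9 nM.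

Among these three numbers compound 1 stands second highest: compound 2 lies a 2.6-fold higher number from compound 1 to compound 2 (0.42 log units; beyond the scatter) away, and compound 3 lies a 2.9-fold lower number from compound 1 to compound 3 (0.46 log units; beyond the scatter) away. Compound 4, `COc1ccc(CNC(=O)c2nn(-c3ccc(F)cc3)c(OC[C@@H](O)C[C@@H](O)CC(=O)O)c2C(C)C)cc1`, differs from compound 1 by (4-methoxybenzyl)amino in place of benzyl(ethyl)amino on a carbonyl carbon. Going by the values given here, the step that bears most on this is the one to compound 3, which likewise replaces benzyl(ethyl)amino and lowers the number modestly; the step of a 7.6-fold lower number from compound 2 to compound 3 (0.88 log units; beyond the scatter) points the same way. Compound 4 is therefore expected to show a modestly lower number, a 2.3-fold lower number from compound 1 to compound 4 (0.37 log units; beyond the scatter). Compound 4 is estimated in this assay at 6 nM, within a range of 2.5 nM to 15 nM.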

Compound 4, half-maximal inhibitory concentration: 12 nM
Compound 4: middle estimate off by 2.0-fold (0.30 log units), on the low side, within the range that was stated.
By their numbers in this assay, from the lowest: compound 3; then compounds 4 and 1 (each within the scatter of the next); then compound 2.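

In this assay, the gain that compound 3 showed over compound 1 does not extend to every benzylamino group that keeps the amide hydrogen, since (4-methoxybenzyl)amino leaves the number unchanged within the scatter (a 1.2-fold lower number from compound 1 to compound 4 (0.07 log units; within the scatter)). The substituent on the benzyl ring therefore counts at this carbonyl carbon (a 2.4-fold higher number from compound 3 to compound 4 (0.39 log units; beyond the scatter)), while compound 4 still stays clear of the methylated amide (a 3.1-fold lower number from compound 2 to compound 4 (0.49 log units; beyond the scatter)). Nothing given here explains these differences. On these data alone, whether the group or its ring place decides remains open, and (3-methoxybenzyl)amino and (4-methylbenzyl)amino would separate the two.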